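A few compounds are considered here, and "the series" means these few. Any claim that something is new, unique, unknown or untested is made for them only; others in the source may bear on it.

In a toxicity assay on L02 cells (Homo sapiens) for cytotoxicity, read by MTT assay, with a stated time of 72 h (on this read-out higher numbers stand for weaker inhibition and lower numbers for stronger inhibition), compound 3 (`CN1CCN(CCCCCCn2c3c(c4ccccc42)C(=O)c2c[n+]([O-])c4ccccc4c2C3=O)CC1`) gives 3800 nM and stands highest of the three numbers, beyond the scatter from both others. Compound 1 (`O=C1c2c[n+]([O-])c3ccccc3c2C(=O)c2c1c1ccccc1n2CCCCn1ccnc1`) gives 150 nM and compound 2 (`CN1CCN(CCCCn2c3c(c4ccccc42)C(=O)c2c[n+]([O-])c4ccccc4c2C3=O)CC1`) gives 80 nM in the same test. These two do not separate, since a 1.9-fold lower number from compound 1 to compound 2 (0.27 log units; within the scatter) stays within the scatter.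

The next change leads to compound 4 (`O=C1c2c[n+]([O-])c3ccccc3c2C(=O)c2c1c1ccccc1n2CCCN1CCC(O)CC1`): 4-hydroxypiperidin-1-yl in place of 3-(4-methylpiperazin-1-yl)propyl on a saturated chain carbon, three bonds along the chain from an aromatic nitrogen.

Going by the values given here, two measured steps bear on this change, and both are large and end at compound 3. The closer one is a 48-fold higher number from compound 2 to compound 3 (1.68 log units; beyond the scatter) for 2-(4-methylpiperazin-1-yl)ethyl in place of 4-methylpiperazin-1-yl. The other is a 25-fold higher number from compound 1 to compound 3 (1.40 log units; beyond the scatter) and starts from the 1H-imidazol-1-yl group. Among the compounds with values here, compound 4 no longer carries the group that compound 3 carries, but no measured compound holds 4-hydroxypiperidin-1-yl, so only part of those steps can be expected to return.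

A large step to a lower number is therefore expected in this assay and is estimated as a 13-fold lower number from compound 3 to compound 4 (1.10 log units; beyond the scatter) in this test. The estimate for compound 4 is 300 nM with an expected range of 70 nM to 1500 nM on this evidence.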

Compound 4, half-maximal inhibitory concentration: 120 nM
Beside the measured number, compound 4's estimate is 2.5-fold (0.40 log units) above it, within the range that was stated.
By their numbers in this assay, from the lowest: compounds 2, 4 and 1 (each within the scatter of the next); then compound 3.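

In this assay, the change to 4-hydroxypiperidin-1-yl at this place, on a saturated chain carbon, three bonds along the chain from an aromatic nitrogen, gives a large step (a 32-fold lower number from compound 3 to compound 4 (1.50 log units; beyond the scatter)), the first one here that ends at an oxygen-bearing ring with a hydrogen-bond donor. Compound 4 does not separate from the compounds with the other two ring ends (a 1.5-fold higher number from compound 2 to compound 4 (0.18 log units; within the scatter); a 1.3-fold lower number from compound 1 to compound 4 (0.10 log units; within the scatter)), so 1H-imidazol-1-yl, 4-methylpiperazin-1-yl and 4-hydroxypiperidin-1-yl all read alike across compounds 1, 2 and 4, and compound 3 alone goes against this grouping. Nothing available on these compounds accounts for the large step or for the lack of separation among the other three.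

From the compounds shown here alone, whether the high number of compound 3 belongs to its longer chain alone stays open, since 4-hydroxypiperidin-1-yl is seen on one chain only and 4-methylpiperazin-1-yl on two. Going by these compounds, how a morpholine ring, a dimethylamino group or a carboxylic acid at the chain end would read in this assay also stays open.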